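Swapping a Carboxy Chain for Methylsulfonyl: Compound 4

The source may hold more compounds than are shown below. What is called first, only, known or untested is meant among the compounds shown, and "the series" means these compounds.

Compound 1, `CCC(CC)(c1ccc(OCCO)c(C)c1)c1ccc(OCC(O)C(C)(C)C)c(OCC(O)C(C)(C)C)c1`: 38%
Compound 2, `CCC(CC)(c1ccc(OCCCCCO)c(C)c1)c1ccc(OCC(O)C(C)(C)C)c(OCC(O)C(C)(C)C)c1`: 67%
Compound 3, `CCC(CC)(c1ccc(OCCCC(=O)O)c(C)c1)c1ccc(OCC(O)C(C)(C)C)c(OCC(O)C(C)(C)C)c1`: 14%

All three compounds were tested in an assay on cells for binding affinity to vitamin D3 receptor (Homo sapiens), read by fluorescence, tested at 1 uM; a lower number here means less inhibition, a higher number more inhibition at the concentration tested (going by the name of the read-out). They share one core and differ only in the group hanging from one oxygen on an aromatic ring. Compound 3, which carries the carboxy-ended chain, gives the lowest number of the three: a number 24 percentage points lower from compound 1 to compound 3 (beyond the scatter), and a number 53 percentage points lower from compound 2 to compound 3 (beyond the scatter). The two hydroxy-ended chains are also apart, since a number 29 percentage points higher from compound 1 to compound 2 (beyond the scatter).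

Compound 4, `CCC(CC)(c1ccc(OS(C)(=O)=O)c(C)c1)c1ccc(OCC(O)C(C)(C)C)c(OCC(O)C(C)(C)C)c1`, is the next compound. Compared with compound 3 the change is methylsulfonyl in place of 3-carboxypropyl on an oxygen on an aromatic ring.

Within the data shown here, no measured step replaces a whole chain by such a short group; the measured steps only alter the end of a chain. They show that the carboxy end sits lowest, and that the hydroxy-ended chains reach modest to higher inhibition. Removing the carboxy end is therefore expected to move the number back toward those compounds, but with wide uncertainty. Compound 4 is expected to give 35%, within 10% to 65%. This would be an expected a number 21 percentage points higher from compound 3 to compound 4 (beyond the scatter).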

Compound 4, a percentage reported as inhibition, at one concentration (the size of the read-out at that concentration, not a potency): "not active" (no number reported)
For compound 4 the study gives words and no number, and the estimate cannot be compared.
By their numbers in this assay, from the lowest: compound 3; then compound 1; then compound 2.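

Among these compounds, compound 4 is reported in this assay only in words, as not active, so no step linking it to compound 3 or any other compound can be read. Nothing measured here accounts for this result.

The compounds shown leave open how much inhibition compound 4 gives on a numerical scale.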